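The source may report more compounds than this note shows. Statements on the series, on what has been measured and on what is new or still open speak of the compounds shown alone.

Working notes on the series. The measured compounds are compound 1 `CCc1cccc2c(O)c(-c3occ(C)c3C(=O)O)ccc12`, compound 2 `CCOc1c(-c2occ(C)c2C(=O)O)ccc2c(CC)cccc12` and compound 3 `CCc1cccc2c(OC)c(-c3occ(C)c3CBr)ccc12`; compound 4 `CCOc1c(-c2occ(C)c2COC)ccc2c(CC)cccc12` is still to be measured. In a functional assay on ZR-75-1 cells (Homo sapiens) for cytotoxicity, read by MTT assay, with a stated time of 72 h (a lower number here means that less compound is needed, a higher number that more compound is needed for the effect), compound 1 gives 0.3 ug/mL. In this assay compound 2 gives > 10 ug/mL, which is a limit of the measurement rather than a number, so that compound 2 sits at the limit of > 10 ug/mL in this assay, at which 1 of the 3 values shown sits. In this assay compound 3 gives 4.6 ug/mL. Among the measured compounds shown here, the one measured single-point step, an at least 33-fold higher number from compound 1 to compound 2 (1.52 log units; beyond the scatter), is large. Compound 4 differs from compound 2 by methoxymethyl in place of carboxy on an aromatic carbon. For the measured compounds named here, no measured step covers this exchange, and compound 2 already stands at the limit, so in this assay no step beyond the scatter is expected. For compound 4 the estimate is 8 ug/mL, between 3 ug/mL and 30 ug/mL. The expected step is an at least 1.2-fold lower number from compound 2 to compound 4 (0.09 log units; that floor lies within the scatter).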

Compound 4, concentration for half-maximal effect: > 10 ug/mL
Compound 4 ended at the assay's limit (the forecaster's own chance of this, stated with the estimate: 50%); middle value at least 1.2-fold (0.09 log units) from the limit.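

Compound 2 and compound 4 both sit at a limit of this assay, so no step can be read between them: the limit of > 10 ug/mL in this assay, at which 2 of the 4 values shown sit. The compounds shown leave open whether methoxymethyl in place of carboxy changes the number in this assay at all.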